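A few compounds are considered here, and "the series" means these few. Any claim that something is new, unique, unknown or untested is made for them only; others in the source may bear on it.

Measured compounds and their values:
compound 1 `Cc1ccc(-c2csc(N/N=C/c3cccs3)n2)cc1`, 98.1%
compound 2 `Fc1ccc(-c2csc(N/N=C/c3cccs3)n2)cc1`, 97%
compound 3 `Clc1ccc(/C=N/Nc2nc(-c3ccccc3)cs2)c(Cl)c1`, 95.8%

The three compounds were tested in a functional assay, read by spectrophotometry, with a stated time of 15 min, tested at 100 ug/mL; on this read-out higher numbers stand for a stronger effect at the one concentration tested and lower numbers for a weaker effect. Compound 1 gives 98.1%, compound 2 gives 97% and compound 3 gives 95.8%. Compound 3 holds the lowest of the three numbers, yet its distance to compound 2 and to compound 1 lies within the scatter, so the three values cannot be told apart.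

The step followed here leads from compound 3 to compound 4 `COc1ccc(-c2csc(N/N=C/c3ccc(Cl)cc3Cl)n2)cc1`, which is still to be measured in this assay. The change is methoxy in place of hydrogen on an aromatic carbon.

Among the measured compounds shown here, the one measured step that bears on it is the exchange of a group on the same kind of aromatic carbon: a number 1.1 percentage points lower from compound 1 to compound 2 (within the scatter). That step stayed within the scatter, and all three measured values sit close to the top of the read-out. No step beyond the scatter is therefore expected from compound 3 to compound 4 in this assay; the expected step is a number 0.7 percentage points higher from compound 3 to compound 4 (within the scatter). Compound 4 is estimated at 96.5%, within a range from 90% to 99.5%.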

Compound 4, a percentage reported as inhibition, at one concentration (the size of the read-out at that concentration, not a potency): 93.3%
Beside the measured number, compound 4's estimate is 3.2 percentage points above it, and the stated range covers the measured number.
By their numbers in this assay, from the lowest: compounds 4, 3, 2 and 1 (each within the scatter of the next).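

In this assay, among the compounds shown here, methoxy in place of hydrogen on an aromatic carbon, para to a large group, gives a number 2.5 percentage points lower from compound 3 to compound 4 (within the scatter), so this change to the core of compound 3 produces no step that can be separated from the scatter. The earlier step, a number 1.1 percentage points lower from compound 1 to compound 2 (within the scatter), exchanged one group for another on a different core, whereas this one starts from hydrogen and is the only comparison shown between an unsubstituted phenyl and a substituted one, here phenyl to 4-methoxyphenyl. No measurement shown gives a reason for this result or bears on what methoxy does at this position.

This single pair does not show whether an amine, a carboxylic acid or a longer chain in the same place would give a step beyond the scatter, or whether methoxy would give a similar step on the core of compound 1. Since the read-out comes from one concentration, where compound 3 gives 95.8% and compound 4 gives 93.3%, it also leaves open whether the two compounds would differ in potency.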